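The source may hold more compounds than are shown below. What is called first, only, known or untested is meant among the compounds shown, and "the series" means these compounds.

In a functional assay on MDA-MB-231 cells (Homo sapiens) for antiproliferative activity, read by MTT assay, with a stated time of 48 h (on this read-out lower numbers stand for stronger inhibition and higher numbers for weaker inhibition), compound 1 `C=CS(=O)(=O)N1CCN(c2ncnc3sc(-c4cn(S(=O)(=O)c5ccccc5)c5ccccc45)cc23)CC1` gives 40400 nM. Compound 2 `C=CS(=O)(=O)N1CCN(c2nc(OC[C@H]3CCCN3C)nc3sccc23)CC1` is reported only as a limit, > 50000 nM. Compound 3 `CCS(=O)(=O)N1CCN(c2ncnc3sc(-c4ccc(N5CCN(C)CC5)cc4)cc23)CC1` gives 7330 nM, the lower of the two actual numbers in this small set, and its gap to compound 1 lies beyond the scatter of repeated measurements.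

The next compound to be tested is compound 4 `CN1CCN(c2ccc(-c3cc4c(N5CCN(C(=O)Nc6ccc(C#N)cc6)CC5)ncnc4s3)cc2)CC1`, which keeps the rest of compound 3 and changes one group: (4-cyanophenyl)carbamoyl in place of ethylsulfonyl on an amine nitrogen in a ring, ((4-cyanophenyl)carbamoyl in place of ethylsulfonyl on an amine nitrogen in a ring). Going by the values given here, no pair of measured compounds differs at this place alone, so the data give no direct guide to the size or direction of this change. The best available anchor is therefore compound 3 at 7330 nM, and the range has to stay wide on both sides.

The expected step is a 1.2-fold lower number from compound 3 to compound 4 (0.09 log units; within the scatter), which would not be expected to lie beyond the scatter, although a larger move in either direction remains possible. For compound 4 the estimated value is 6000 nM, with an expected range from 1500 nM to 25000 nM.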

Compound 4, half-maximal inhibitory concentration: 3930 nM
Beside the measured number, compound 4's estimate is 1.5-fold (0.18 log units) above it; the range from low to high includes it.
By their numbers in this assay, from the lowest: compounds 4 and 3 (each within the scatter of the next); then compound 1. At a limit, above all of these: compound 2.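

In this assay, going by these compounds alone, placing (4-cyanophenyl)carbamoyl instead of ethylsulfonyl on the amine nitrogen in a ring gives a 1.9-fold lower number from compound 3 to compound 4 (0.27 log units; within the scatter), the first step in this set that can be read at a single place. The entering group brings a six-membered aromatic ring of carbon only, a nitrile and a hydrogen-bond donor, while the leaving group has no ring and no donor, yet the two numbers cannot be told apart, so this large difference in structure leaves the read-out within the scatter. The compounds shown offer no measurement that accounts for this outcome.

Going by these compounds, what remains open is whether this nitrogen is as undemanding for other groups, such as a small acetyl, a free amine or a longer alkyl chain, and whether a carboxylic acid in place of the nitrile would leave the number where it is. Within the data shown here, with only one step at this place, it is also unknown whether the same exchange would give a similar result with a different group on the far side of the shared core.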